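The source may report more compounds than this note shows. Statements on the series, on what has been measured and on what is new or still open speak of the compounds shown alone.

In a physicochemical assay for solubility, read by HPLC, using the shake flask method, in phosphate buffer, with a stated time of 2 h, at pH 6.5 (a higher number here means a more soluble compound, a lower number a less soluble compound), the amides built on the shared core cover a wide span. Compound 1 `Nc1ncc(-c2ccc(C(=O)N3CC(O)C3)cc2)nc1-c1ccc(C(F)(F)F)cc1` gives 55000 nM. Compound 2 `NC(=O)c1ccc(-c2cnc(N)c(-c3ccc(C(F)(F)F)cc3)n2)cc1` gives < 5000 nM, which is a limit of the assay and not a number. Compound 3 `Nc1ncc(-c2ccc(C(=O)N3CCC(N)CC3)cc2)nc1-c1ccc(C(F)(F)F)cc1` gives 88000 nM. It stands level with compound 1, the measured step being a 1.6-fold higher number from compound 1 to compound 3 (0.20 log units; within the scatter). Compound 2 lies well apart from both, with an at least 11-fold lower number from compound 1 to compound 2 (1.04 log units; beyond the scatter) and an at least 17-fold higher number from compound 2 to compound 3 (1.24 log units; beyond the scatter).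

The next compound is compound 4 `Nc1ncc(-c2ccc(C(=O)N3CCC(O)C3)cc2)nc1-c1ccc(C(F)(F)F)cc1`, in which 3-hydroxypyrrolidin-1-yl takes the place of 4-aminopiperidin-1-yl on a carbonyl carbon (3-hydroxypyrrolidin-1-yl in place of 4-aminopiperidin-1-yl on a carbonyl carbon). Among the compounds with values here, the closest precedent is the exchange of 3-hydroxyazetidin-1-yl for 4-aminopiperidin-1-yl, which between compound 1 and compound 3 amounted to a 1.6-fold higher number from compound 1 to compound 3 (0.20 log units; within the scatter). The two large steps both involve the plain amino of compound 2, a group that plays no part in the present change, so they bear on it only weakly. Compound 4 is therefore expected to stay close to compound 1 at 55000 nM. The expected change is a 1.8-fold lower number from compound 3 to compound 4 (0.25 log units; within the scatter), so no step beyond the scatter is anticipated. For compound 4 the estimated value is 50000 nM, with an expected range from 20000 nM to 120000 nM.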

Compound 4, solubility: 77000 nM
Compound 4: middle estimate off by 1.5-fold (0.19 log units), on the low side, within the range that was stated.
By their numbers in this assay, from the lowest: compounds 1, 4 and 3 (each within the scatter of the next). At a limit, below all of these: compound 2.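

In this assay, the change on this carbonyl carbon from 4-aminopiperidin-1-yl to 3-hydroxypyrrolidin-1-yl makes no difference that can be told from the scatter, with a 1.1-fold lower number from compound 3 to compound 4 (0.06 log units; within the scatter), and the same holds for the exchange of 3-hydroxyazetidin-1-yl for 3-hydroxypyrrolidin-1-yl, with a 1.4-fold higher number from compound 1 to compound 4 (0.15 log units; within the scatter). Compounds 1, 3 and 4 therefore read as one level across three different ring groups, with either a hydroxyl or an amino group on the ring, and the large gap to the plain amide now appears with a third partner, as an at least 15-fold higher number from compound 2 to compound 4 (1.18 log units; beyond the scatter). That step is a bound and not a measured distance, since the value of compound 2 is a limit of the assay: the limit of < 5000 nM in this assay, at which 1 of the 4 values shown sits.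

The compounds shown leave open how far below this level compound 2 truly lies, and so how large the gap to the ring-bearing amides really is. They also leave open whether the level would hold with an open-chain group on the amide nitrogen, such as a 2-aminoethyl chain, or with a carboxylic acid on the ring in place of the hydroxyl or amino group.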